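Replacing Hydroxy with Pyridin-4-yl on the Amide Nitrogen

A few compounds are considered here, and "the series" means these few. Any claim that something is new, unique, unknown or untested is made for them only; others in the source may bear on it.

Compound 1 `O=C(/C=C/[C@H]1C[C@@H](O)[C@@H](O)C1)Nc1ccccc1` was tested in an ADME assay on S2 cells (Drosophila melanogaster) for cytotoxicity, read by MTT assay (a higher number here means that more compound is needed for the effect, a lower number that less compound is needed), and gave > 200000 nM, which is a limit of the assay rather than a number. Compound 2 `O=C(/C=C/[C@H]1C[C@@H](O)[C@@H](O)C1)NO` likewise gave > 250000 nM, again only a limit. The step that the two limits leave unreadable from compound 1 to compound 2 therefore cannot be sized, since both values sit at limits (the limit of > 200000 nM in this assay, at which 1 of the 2 values shown sits, (the limit of > 250000 nM in this assay, at which 1 of the 2 values shown sits)). Compound 3 `O=C(/C=C/[C@H]1C[C@@H](O)[C@@H](O)C1)Nc1ccncc1` differs from compound 2 by pyridin-4-yl in place of hydroxy on an amide-type nitrogen. For the measured compounds named here, no measured step bears on this change, and compound 2 itself stands only at a limit. Compound 3 is therefore expected to give an estimated 250000 nM (range 100000 nM to 1000000 nM). For compound 3 this means an expected step of a number no higher from compound 2 to compound 3 (the limit leaves the size open).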

Compound 3, half-maximal effective concentration: > 200000 nM
Compound 3: only a limit was reported; the forecaster's own chance of this, stated with the estimate: 80%; the middle value is on the limit's open side.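

Compound 3 gives only a limit in this assay, so neither its step from compound 1 nor its step from compound 2 can be read: the limit of > 200000 nM in this assay, at which 2 of the 3 values shown sit.

From the compounds shown here alone, whether phenyl, hydroxy and pyridin-4-yl on an amide-type nitrogen differ at all in this assay stays open.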